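The source may hold more compounds than are shown below. What is called first, only, known or untested is meant among the compounds shown, and "the series" means these compounds.

Compound 3 `Cc1ccc(CN2CCC(O)(Cn3cnc4c(cnn4-c4ccc(F)cc4)c3=O)CC2)cc1` carries a 4-methylbenzyl group on the shared core. In an assay on Sf21 cells for inhibition of ubiquitin carboxyl-terminal hydrolase 7 (Homo sapiens), read by spectrophotometry, with stated times of 30 min and 2 h (a higher number here means a weaker inhibitor, a lower number a stronger inhibitor), compound 3 gives "not determined" (no result reported), so no number stands for it. Two close relatives were measured: compound 1 `O=c1c2cnn(-c3ccc(F)cc3)c2ncn1CC1(O)CCN(Cc2ccccc2Cl)CC1` and compound 2 `O=c1c2cnn(-c3ccc(F)cc3)c2ncn1CC1(O)CCN(Cc2ccccc2Br)CC1`. In this assay, among the compounds with values here, compound 1 gives 3400 nM and compound 2 gives 3100 nM, and the only single-change step known is a 1.1-fold lower number from compound 1 to compound 2 (0.04 log units; within the scatter), a swap of one halogen for another. Compound 4 `COC(=O)c1ccc(CN2CCC(O)(Cn3cnc4c(cnn4-c4ccc(F)cc4)c3=O)CC2)cc1` differs from compound 3 by methoxycarbonyl in place of methyl on an aromatic carbon. Within the data shown here, no measured step touches this kind of change, and the halogen swap offers little guidance, so there is no basis for expecting a shift beyond the scatter in this assay. Compound 4 is therefore expected at an estimated 3000 nM, with a range of 800 nM to 12000 nM. That estimate simply sits close to where compound 1 and compound 2 stand.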

Compound 4, half-maximal inhibitory concentration: 4500 nM
The estimate for compound 4 lay 1.5-fold (0.18 log units) below the measured number; measured number inside the range.
By their numbers in this assay, from the lowest: compounds 2, 1 and 4 (each within the scatter of the next).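

In this assay both a 1.5-fold higher number from compound 2 to compound 4 (0.16 log units; within the scatter) and a 1.3-fold higher number from compound 1 to compound 4 (0.12 log units; within the scatter) lie within the scatter, so the 4-(methoxycarbonyl)benzyl group, with its larger substituent, stands level with the two halogen-bearing benzyl groups. These steps change both the group and its place on the ring, and the swap of methyl for methoxycarbonyl cannot be read, since compound 3 has no number. Nothing available explains why these numbers stay so close. Going by these compounds, whether a carboxylic acid or an amine in place of the methoxycarbonyl would shift the number beyond the scatter stays open. So does whether any group on this ring can do so.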